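Adding a Hydroxyl to the Chlorophenyl Arm

A few compounds are considered here, and "the series" means these few. Any claim that something is new, unique, unknown or untested is made for them only; others in the source may bear on it.

Among the measured compounds shown here, compound 1 `COc1cccc(/C=C2\CCC/C(=C\c3ccccc3Cl)C2=O)c1OC` was tested in an ADME assay on NHDF cells (Homo sapiens) for cytotoxicity, read by MTT assay, with a stated time of 72 h (a higher number here means a weaker inhibitor, a lower number a stronger inhibitor), where compound 1 gives 44200 nM, the highest of the three numbers known so far. For the measured compounds named here, compound 2 `COc1ccccc1/C=C1\CCC/C(=C\c2cccc(OC)c2OC)C1=O` gives 31300 nM, and the one change between them, a 1.4-fold lower number from compound 1 to compound 2 (0.15 log units; within the scatter), shifts nothing beyond the scatter. Compound 3 `COc1cccc(/C=C2\CCC/C(=C\c3ccc(Cl)c(Cl)c3)C2=O)c1OC` gives 25500 nM. Compound 4 `COc1cccc(/C=C2\CCC/C(=C\c3ccc(O)c(Cl)c3)C2=O)c1OC` differs from compound 1 in one place: 3-chloro-4-hydroxyphenyl in place of 2-chlorophenyl on a double-bonded chain carbon bound to a double-bonded ring carbon. Going by the values given here, the steps that bear on this are those that exchanged the group on that same chain carbon, a 1.7-fold lower number from compound 1 to compound 3 (0.24 log units; within the scatter) and a 1.2-fold lower number from compound 2 to compound 3 (0.09 log units; within the scatter), both small. Compound 4 is therefore expected to show no step beyond the scatter, a 1.2-fold lower number from compound 1 to compound 4 (0.07 log units; within the scatter). The estimate for compound 4 is 38000 nM, with a range from 15000 nM to 95000 nM.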

Compound 4, half-maximal inhibitory concentration: 39500 nM
Compound 4: the middle estimate sits 1.0-fold (0.02 log units) below what was measured; low and high end bracket the measured number.
By their numbers in this assay, from the lowest: compounds 3, 2, 4 and 1 (each within the scatter of the next).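

Placing 3-chloro-4-hydroxyphenyl on this chain carbon adds a hydrogen-bond donor to the arm, yet this assay barely registers it: the exchange for 2-chlorophenyl gives a 1.1-fold lower number from compound 1 to compound 4 (0.05 log units; within the scatter) and hydroxy in place of chloro gives a 1.5-fold higher number from compound 3 to compound 4 (0.19 log units; within the scatter) while the exchange for 2-methoxyphenyl gives a 1.3-fold higher number from compound 2 to compound 4 (0.10 log units; within the scatter). This position has now carried chloro, methoxy and hydroxy groups with no step beyond the scatter. Nothing available explains this flat result. Still open, going by these compounds, is whether an amine or a carboxylic acid on this arm would move the number beyond the scatter.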